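Adding a Fluorine to a Weak Cytotoxic Amide

The source may report more compounds than this note shows. Statements on the series, on what has been measured and on what is new or still open speak of the compounds shown alone.

Measured so far:
- compound 1, `COc1ccc(-c2ccnc(C(=O)Nc3ccc(Oc4ccnc5[nH]ccc45)cc3)n2)cc1`: 12400 nM
- compound 2, `O=C(Nc1ccc(Oc2ccnc3[nH]ccc23)cc1)c1nccc(-c2ccc(F)cc2)n1`: "not active" (no number reported)

In a functional assay on MCF7 cells (Homo sapiens) for cytotoxicity, read by MTT assay, with a stated time of 72 h (a lower number here means a stronger inhibitor, a higher number a weaker inhibitor), compound 1 gives 12400 nM, which is a weak result. Compound 2, `O=C(Nc1ccc(Oc2ccnc3[nH]ccc23)cc1)c1nccc(-c2ccc(F)cc2)n1`, is reported as "not active" (no number reported) in this assay, without any number. Compound 1 therefore holds the only number shown; it is not possible to compare these two compounds more closely.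

The next compound, compound 3, `COc1ccc(-c2ccnc(C(=O)Nc3ccc(Oc4ccnc5[nH]ccc45)c(F)c3)n2)cc1`, keeps the shared core of compound 1 and differs in one place: fluoro in place of hydrogen on an aromatic carbon. For the measured compounds named here, no measured pair of this kind exists here, so the size of the step is unknown. A single fluorine added in this way is expected to move this assay little, and any step from compound 1 to compound 3 is expected to stay within the usual scatter, as a 1.2-fold lower number from compound 1 to compound 3 (0.09 log units; within the scatter) expresses. Compound 3 is thus estimated at 10000 nM, with a range from 3500 nM to 30000 nM.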

Compound 3, half-maximal inhibitory concentration: 8960 nM
The estimate for compound 3 lay 1.1-fold (0.05 log units) above the measured number, within the range that was stated.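

In this assay, for the compounds shown here, fluoro in place of hydrogen on an aromatic carbon, ortho to a large group and meta to a large group, gives a 1.4-fold lower number from compound 1 to compound 3 (0.14 log units; within the scatter) and provides the first step that can be read. Going by these compounds alone, until now, no measured pair differing in one place existed, whereas this pair shows that a single fluorine at this position leaves the number indistinguishable from that of compound 1 and does not, on its own, lift the series out of the weak range. No measured information is available to explain this result.

Going by these compounds, it remains open whether an amine or a carboxylic acid on this same aromatic carbon would produce a step beyond the scatter. Compound 2 has no number, so it cannot show how fluoro behaves elsewhere in the molecule.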